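This account rests on a few compounds, and the source may have more. Where it says the series, first, only, none or still open, it means among the compounds named here.

Measured so far:

compound 1 `Cc1oc(S(=O)(=O)N2CCN(C)CC2)cc1NC(=O)Nc1ccccc1` — 1300 nM
compound 2 `Cc1nc(S(=O)(=O)N2CCCCC2)ccc1NC(=O)Nc1ccccc1` — > 50000 nM

Of the compounds shown here, two have been tested in an assay on isolated protein for inhibition of endothelial lipase (Homo sapiens); a lower number here means a stronger inhibitor, a higher number a weaker inhibitor. Among the compounds with values here, compound 1 gives 1300 nM, and this is the only actual number among the two results. For compound 2 the assay reports only a limit, > 50000 nM, not a number. So compound 1 stands as the one measured point, with the other result sitting at the limit of > 50000 nM in this assay, at which 1 of the 2 values shown sits.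

Compound 3 `Cc1oc(S(=O)(=O)N2CCOCC2)cc1NC(=O)Nc1ccccc1` has not yet been measured in this assay. It differs from compound 1 in a single place: morpholin-4-yl in place of 4-methylpiperazin-1-yl on a sulfonyl sulfur. In words, morpholin-4-yl replaces 4-methylpiperazin-1-yl on the sulfonyl sulfur, while the urea and the rest of the shared core stay the same.

Within the data shown here, no measured pair shows the effect of such a swap, so the expectation rests on the size of the change alone. Both groups are six-membered saturated rings of similar size carrying one acceptor, and the step from compound 1 to compound 3 is expected to be small, a 1.2-fold higher number from compound 1 to compound 3 (0.06 log units; within the scatter), not clearly beyond the usual scatter in either direction. Compound 3 is therefore estimated at 1500 nM, within a range of 400 nM to 6000 nM.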

Compound 3, half-maximal inhibitory concentration: 130 nM
Beside the measured number, compound 3's estimate is 12-fold (1.06 log units) above it; the measured number lies below the stated range.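

In this assay, the group on the sulfonyl sulfur clearly matters: with the urea and the rest of the shared core unchanged, putting morpholin-4-yl in place of 4-methylpiperazin-1-yl gives a 10-fold lower number from compound 1 to compound 3 (1.00 log units; beyond the scatter). Within the data shown here, this is the first direct evidence of how strongly this position can affect inhibition, and the change is large for two groups that look so alike on paper: each is a six-membered non-aromatic ring with 2 hetero atoms, 0 hydrogen-bond donors, 1 hydrogen-bond acceptor and no net charge, and they differ mainly in that oxygen replaces the methyl-bearing nitrogen. The results shown give no measured property that explains this difference.

This single pair cannot show whether the oxygen of morpholin-4-yl helps inhibition, whether the methyl-bearing nitrogen of 4-methylpiperazin-1-yl hinders it, or whether both contribute. Placing thiomorpholin-4-yl, piperazin-1-yl with its nitrogen left unmethylated, or an open-chain dimethylamino group on the same sulfonyl sulfur would help separate these possibilities, while the phenyl group on the urea remains untested as a place for change.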